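Working notes: chloro in place of fluoro on compound 2

The source may hold more compounds than are shown below. What is called first, only, known or untested is meant among the compounds shown, and "the series" means these compounds.

Of the compounds shown here, two have been read so far in a functional assay on NC-37 cells (Homo sapiens) for cytotoxicity; a higher number here means that more compound is tolerated, a lower number that less compound is tolerated. Compound 1 `C[C@H]1[C@H](O)[C@@H](CO)O[C@H]1n1cc(Cl)c(=O)[nH]c1=O` gives > 100 ug/mL, which is a limit of the assay and not a number. Going by the values given here, compound 2 `C[C@H]1[C@H](O)[C@@H](CO)O[C@H]1n1cc(F)c(N)nc1=O` gives 0.22 ug/mL, the only true number, so there is no other number to rank it against. Compound 3 `C[C@H]1[C@H](O)[C@@H](CO)O[C@H]1n1cc(Cl)c(N)nc1=O` comes from compound 2 by one exchange, chloro in place of fluoro on an aromatic carbon, ortho to an amino group: chloro in place of fluoro on an aromatic carbon. Among the compounds with values here, no measured pair isolates this exchange in this assay, so its size is a judgement. A moderate shift toward more compound tolerated is expected, though a result within the scatter remains possible. The expected change is a 6.8-fold higher number from compound 2 to compound 3 (0.83 log units; beyond the scatter). Compound 3 is estimated at 1.5 ug/mL, with an expected range of 0.2 ug/mL to 20 ug/mL.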

Compound 3, half-maximal cytotoxic concentration: > 100 ug/mL
Compound 3 ended at the assay's limit; the forecaster's own chance of this, stated with the estimate: 8%; middle value at least 66-fold (1.82 log units) from the limit.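

In this assay, going by these compounds alone, chloro in place of fluoro on the aromatic carbon ortho to an amino group gives an at least 450-fold higher number from compound 2 to compound 3 (2.65 log units; beyond the scatter), so this one position can carry a very large change from a swap of a single heavy atom, which no earlier pair could show. Compound 3 gives > 100 ug/mL, which is a limit of the assay and not a number. The step therefore sets only a lower bound on the size of this change, and its true size cannot be read: the limit of > 100 ug/mL in this assay, at which 2 of the 3 values shown sit.

The compounds shown leave open whether the steep change is specific to fluoro or whether other groups on this carbon, such as hydrogen, methyl or a nitrile, would also keep the number low. They also leave open how far the chloro compound lies past the limit.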